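A few compounds are considered here, and "the series" means these few. Any claim that something is new, unique, unknown or untested is made for them only; others in the source may bear on it.

Measured in a functional assay on HeLa cells (Homo sapiens) for antiproliferative activity, with a stated time of 24 h; a lower number here means a stronger inhibitor, a higher number a weaker inhibitor:

Compound 1 `NC(=O)c1c(NC(=O)c2ccccc2F)sc2c1CCN(Cc1ccc(Cl)cc1Cl)C2`: 27500 nM
Compound 2 `NC(=O)c1c(NC(=O)c2ccccc2Cl)sc2c1CCN(C(=S)Nc1cccc3ccccc13)C2`: 30800 nM
Compound 3 `NC(=O)c1c(NC(=O)c2ccccc2F)sc2c1CCN(C(=S)Nc1cc(C(F)(F)F)cc(C(F)(F)F)c1)C2`: 28000 nM

All three compounds share one core, and their numbers lie close together: compound 3 sits within the usual scatter of compound 1 and of compound 2, so the three values cannot be told apart. Compound 4 `Cc1ccc(C(=O)Nc2sc3c(c2C(N)=O)CCN(C(=S)Nc2cc(C(F)(F)F)cc(C(F)(F)F)c2)C3)cc1` is not yet measured. It differs from compound 3 in one place: 4-methylphenyl in place of 2-fluorophenyl on a carbonyl carbon. Going by the values given here, no measured pair shows what this kind of change does, so there is no known step to lean on. Given how tightly the three known values cluster, the expected step is no change at the digits printed from compound 3 to compound 4 (within the scatter), that is, none beyond the scatter. Compound 4 is therefore expected to give about 28000 nM in this assay, within a range from 12000 nM to 65000 nM.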

Compound 4, half-maximal inhibitory concentration: 17100 nM
The estimate for compound 4 lay 1.6-fold (0.21 log units) above the measured number, within the range that was stated.
By their numbers in this assay, from the lowest: compounds 4, 1, 3 and 2 (each within the scatter of the next).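

Going by these compounds alone, this is the first measured pair to vary the group on this carbonyl carbon: in this assay, putting 4-methylphenyl in place of 2-fluorophenyl gives a 1.6-fold lower number from compound 3 to compound 4 (0.21 log units; within the scatter). This one swap therefore leaves the activity indistinguishable, so the two aryl groups cannot be ranked. No measured evidence bears on this result.

On these data alone, it remains open what a group of a different kind on this carbonyl carbon would do, such as a longer alkyl chain or a phenyl ring carrying an amine or a carboxylic acid.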